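The source may hold more compounds than are shown below. What is called first, only, known or untested is meant among the compounds shown, and "the series" means these compounds.

Measured so far in a functional assay on MDA-MB-231 cells (Homo sapiens) for cytotoxicity, read by sulforhodamine B assay, with a stated time of 72 h; on this read-out lower numbers stand for stronger inhibition of growth and higher numbers for weaker inhibition of growth:
compound 1 `CCCC(=O)N1c2ccccc2CCC1C(=O)Nc1cc(C(F)(F)F)cc(C(F)(F)F)c1` gives 15200 nM
compound 2 `O=C(Nc1cc(C(F)(F)F)cc(C(F)(F)F)c1)C1CCc2ccccc2N1` gives 8270 nM

For the measured compounds named here, compound 2 holds the lower of the two numbers; its nearest neighbour is compound 1, and the only measured step, a 1.8-fold lower number from compound 1 to compound 2 (0.26 log units; within the scatter), lies within the scatter, so no order between the two is claimed.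

Compound 3 `CCC(=O)N1c2ccccc2CCC1C(=O)Nc1cc(C(F)(F)F)cc(C(F)(F)F)c1` is not yet measured. It differs from compound 2 by propanoyl in place of hydrogen on a nitrogen on an aromatic ring in a ring. Going by the values given here, the one step that bears on this change is a 1.8-fold lower number from compound 1 to compound 2 (0.26 log units; within the scatter), which removed a propylcarbonyl from the same nitrogen and stayed within the scatter. Compound 3 carries a shorter acyl group on that nitrogen than compound 1 does, so a number between those of compound 1 and compound 2 is expected, with a step of a 1.5-fold higher number from compound 2 to compound 3 (0.16 log units; within the scatter) that should itself stay within the scatter. The estimate for compound 3 in this assay is 12000 nM, with a range of 5000 nM to 28000 nM.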

Compound 3, concentration for 50% growth inhibition: 7280 nM
Estimate against measurement, compound 3: 1.6-fold (0.22 log units) above; the measured number falls inside the stated range.
By their numbers in this assay, from the lowest: compounds 3, 2 and 1 (each within the scatter of the next, the first and the last beyond it).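

In this assay, propanoyl in place of hydrogen on the nitrogen gives a 1.1-fold lower number from compound 2 to compound 3 (0.06 log units; within the scatter), so at this position neither of the two acyl groups shown moves the number beyond the scatter from that of the free nitrogen. Hydrogen in place of methyl on the saturated chain carbon, two bonds along the chain from a carbonyl carbon, gives a 2.1-fold lower number from compound 1 to compound 3 (0.32 log units; beyond the scatter), a modest step and the only one here beyond the scatter, which makes acyl chain length the one change in this set with a readable difference. No measurement at hand accounts for that difference.

From the compounds shown here alone, whether the step extends into a trend remains open, and acetyl, a longer chain such as pentanoyl, or an amine at the chain end would test this. All the compounds shown carry the two trifluoromethyl groups, so the part these groups play in the number also stays open.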